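A sulfanyl linker replaces the benzylamine of compound 1

The source may hold more compounds than are shown below. What is called first, only, known or untested is meant among the compounds shown, and "the series" means these compounds.

Compound 1 `Nc1cc(N)c2nc(-c3ccccc3)c(NCc3ccc(F)cc3)nc2c1` is measured in a functional assay on OVCAR-3 cells (Homo sapiens) for inhibition, read by sulforhodamine B assay, with a stated time of 48 h (on this read-out higher numbers stand for weaker inhibition of growth and lower numbers for stronger inhibition of growth), at 6460 nM, the lower of the two numbers in hand. For the measured compounds named here, its only neighbour, compound 2 `COc1ccc(CNc2nc3cc(N)cc(N)c3nc2-c2ccccc2)cc1`, gives 7760 nM in this assay; the step from a 1.2-fold higher number from compound 1 to compound 2 (0.08 log units; within the scatter) shows that the two lie within the scatter of each other. Compound 3 `Nc1cc(N)c2nc(-c3ccccc3)c(Sc3ccc(F)cc3)nc2c1` keeps the core and the phenyl group of compound 1 but alters the side group: (4-fluorophenyl)sulfanyl in place of (4-fluorobenzyl)amino on an aromatic carbon. Going by the values given here, no measured step mirrors this exchange; the single known step concerns only fluoro against methoxy on the benzyl ring and is flat, so it offers little guidance on replacing the whole linker. Among the compounds with values here, because compound 1 sits at 6460 nM and the one comparison is flat, compound 3 is expected to land near it, if anything somewhat weaker. The estimated step is a 1.5-fold higher number from compound 1 to compound 3 (0.19 log units; within the scatter) for compound 3. The estimate for compound 3 in this assay is 10000 nM, with a range from 3000 nM to 35000 nM.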

Compound 3, concentration for total growth inhibition: 33900 nM
The estimate for compound 3 lay 3.4-fold (0.53 log units) below the measured number; low and high end bracket the measured number.
By their numbers in this assay, from the lowest: compounds 1 and 2 (each within the scatter of the next); then compound 3.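

In this assay, putting (4-fluorophenyl)sulfanyl in place of (4-fluorobenzyl)amino gives a 5.2-fold higher number from compound 1 to compound 3 (0.72 log units; beyond the scatter) and so means weaker inhibition of growth, whereas the earlier change on the benzyl ring, a 1.2-fold higher number from compound 1 to compound 2 (0.08 log units; within the scatter), had stayed flat. This position therefore responds to a change of the whole side group in a way that the exchange of fluoro for methoxy did not reveal. The exchange alters the linking atoms and removes the benzyl carbon together, and nothing available explains the loss.

On these data alone, what stays open is which part of the exchange carries the step. A (4-fluorophenyl)amino group or a (4-fluorobenzyl)sulfanyl group on the same carbon would separate the effect of sulfur from that of the missing benzyl carbon.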